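A few compounds are considered here, and "the series" means these few. Any claim that something is new, unique, unknown or untested is made for them only; others in the source may bear on it.

Measured so far in a functional assay on PANC-1 cells (Homo sapiens) for inhibition, read by MTT assay, with a stated time of 24 h, tested at 10 uM; on this read-out lower numbers stand for less inhibition and higher numbers for more inhibition at the one concentration tested (going by the name of the read-out):

compound 1 `COc1ccc(NC(=O)Oc2cc(=O)n(CCCO)c3c2CC(CC=C(C)C)C(C)(C)C3)cc1` gives 3.7%
compound 2 `CC(C)=CCC1Cc2c(OC(=O)Nc3ccc(Cl)cc3)cc(=O)n(CCCO)c2CC1(C)C` gives 49.8%
compound 3 `COc1ccc(OCCCOc2cc(=O)n(CCCO)c3c2CC(C/C=C(\C)CCC=C(C)C)C(C)(C)C3)cc1` gives 20%

Compound 1 and compound 2 share one core and differ in a single place: chloro in place of methoxy on an aromatic carbon. That change carries a number 46.1 percentage points higher from compound 1 to compound 2 (beyond the scatter), a step well beyond the scatter, and it is the largest movement seen so far in this series.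

Compound 3 carries a different core from compound 1; the difference between the two cores is not broken down here. On that core the not yet measured compound 4 `CC(C)=CCC/C(C)=C/CC1Cc2c(OCCCOc3ccc(Cl)cc3)cc(=O)n(CCCO)c2CC1(C)C` repeats the same change: chloro in place of methoxy on an aromatic carbon. The place of the change reads the same in both pairs, on an aromatic carbon of a six-membered aromatic ring of carbon only, para to a large group, so the change from compound 3 to compound 4 is taken as the same change as that from compound 1 to compound 2, though it is applied on a core whose relation to the first is not counted.

Within the data shown here, compound 4 is expected to move by about a number 25 percentage points higher from compound 3 to compound 4 (beyond the scatter) in this assay, a step estimated to be in the same direction as the earlier one but taken with a wider margin, because only the single step of a number 46.1 percentage points higher from compound 1 to compound 2 (beyond the scatter) supports it and that step was measured on the other core. For compound 4 the estimate is 45%, with a likely range from 22% to 68%.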

Compound 4, a percentage reported as inhibition, at one concentration (the size of the read-out at that concentration, not a potency): 25.2%
The estimate for compound 4 lay 19.8 percentage points above the measured number; measured number inside the range.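

In this assay, chloro in place of methoxy on an aromatic carbon, para to a large group, comes with a number 5.2 percentage points higher from compound 3 to compound 4 (within the scatter), so the large gain seen on the core of compound 1 does not reappear on the other core. The change therefore cannot be carried between these two cores as a step of fixed size, and its effect in this series depends on the core that carries it: the same change on two cores in this assay, a number 46.1 percentage points higher (beyond the scatter) from compound 1 to compound 2 and a number 5.2 percentage points higher (within the scatter) from compound 3 to compound 4, 40.9 percentage points apart, beyond the scatter of two such steps

This does not show which part of the difference between the two cores accounts for the gap, and two pairs give no rule for predicting the step on any further core. Nor does it show that chloro and methoxy would stay within the scatter of each other on related cores.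

From the compounds shown here alone, only methoxy and chloro appear at this aromatic position, so it remains open how fluoro, trifluoromethyl, a nitrile, an amine or a carboxylic acid there would behave on either core. Also open, going by these compounds, is whether a shorter or longer chain between the aromatic ring and the core would bring the step on the core of compound 3 closer to that on the core of compound 1.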